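The compounds below may be only part of what the source reports. "The series", "measured", "known", "first", "only" and "open" are said of these compounds alone.

Compound 1 `COc1ccc(-c2cccc(C(=O)N(C)C)c2)cc1S(=O)(=O)Nc1ccc2ccc(NC(=O)c3ccccc3)cc2c1` in a functional assay on CHO cells for agonist activity at Orexin receptor type 2 (Homo sapiens) (a higher number here means that more compound is needed for the effect, a lower number that less compound is needed), gives a limit of > 10000 nM. Compound 2 `COc1ccccc1C(=O)N(C)c1cccc2ccc(NS(=O)(=O)c3cc(-c4cccc(C(=O)N(C)C)c4)ccc3OC)cc12` gives a limit of > 10000 nM in this assay.

Among the compounds with values here, compound 2 therefore stands only at a limit, and the one other value shown is a limit as well (the limit of > 10000 nM in this assay, at which 2 of the 2 values shown sit). Compound 3 `COc1ccc(C(=O)N(C)c2cccc3ccc(NS(=O)(=O)c4cc(-c5cccc(C(=O)N(C)C)c5)ccc4OC)cc23)cc1` differs from compound 2 by 4-methoxyphenyl in place of 2-methoxyphenyl on a carbonyl carbon, in words 4-methoxyphenyl in place of 2-methoxyphenyl on a carbonyl carbon. Within the data shown here, no step between measured compounds is available to lean on; the expected step is a step that the limit leaves unreadable from compound 2 to compound 3, nothing beyond the scatter. Compound 3 is estimated at 15000 nM, within a range from 3000 nM to 60000 nM, most likely again reported only as a limit.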

Compound 3, half-maximal effective concentration: 51.1 nM
Compound 3: the middle estimate sits 290-fold (2.47 log units) above what was measured; the whole stated range lies above it.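

Within the data shown here, the methoxy position on this phenyl ring can decide the outcome: with the atoms otherwise unchanged, 4-methoxyphenyl in place of 2-methoxyphenyl on a carbonyl carbon gives an at least 190-fold lower number from compound 2 to compound 3 (2.29 log units; beyond the scatter) in this assay and turns a limit into the first measured value of the series. From the compounds shown here alone, the true size of this step stays unknown because compound 2 is reported only as a limit: the limit of > 10000 nM in this assay, at which 2 of the 3 values shown sit.

Going by these compounds, it remains open whether the methoxy group itself is needed, or whether a hydroxy group, a fluorine or an amine would serve on that ring.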